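Swapping the pyridine attachment on a fused bicyclic core

The compounds below may be only part of what the source reports. "The series", "measured", "known", "first", "only" and "open" are said of these compounds alone.

The series centres on an anilino-substituted fused bicyclic core carrying a pyridyl ring, tested in a functional assay on the whole organism (Abdomen, strain Swiss) for inhibition, with Mus musculus as the target, with a stated time of 1 h, at a dose of 100 umol/kg by the oral route; on this read-out higher numbers stand for more inhibition at the one dose given (going by the name of the read-out) and lower numbers for less inhibition. Compound 1, `CS(=O)(=O)c1ccc(Nc2c(-c3ccccn3)nc3ccccn23)cc1`, bears a methylsulfonyl group on the anilino ring and a pyridin-2-yl group; in this assay compound 1 gives 33.7%. Compound 2, `c1ccc(Nc2c(-c3ccncc3)nc3ccccn23)cc1`, has an unsubstituted anilino group and a pyridin-4-yl group; in this assay compound 2 gives 13%, the lower of the two numbers, and the gap to compound 1 lies beyond the usual scatter of the measurement.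

Compound 3, `c1ccc(Nc2c(-c3ccccn3)nc3ccccn23)cc1`, has not yet been measured. It differs from compound 2 in one place: pyridin-2-yl in place of pyridin-4-yl on an aromatic carbon. Both compounds keep the unsubstituted anilino group, so this change isolates the pyridine attachment. Going by the values given here, compound 1, the only measured compound with a pyridin-2-yl group, sits higher than compound 2, but it also carries the methylsulfonyl group, so its value cannot be attributed to the pyridine alone.

The step from compound 2 to compound 3 is expected to be a modest rise, a number 9 percentage points higher from compound 2 to compound 3 (within the scatter), possibly within the scatter. Compound 3 is estimated at 22%, with a range from 5% to 40%.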

Compound 3, a percentage reported as inhibition, in the whole organism at one dose (the size of the read-out at that dose, not a potency): -3%
Estimate against measurement, compound 3: 25 percentage points above; measured number below the stated range.
By their numbers in this assay, from the lowest: compound 3; then compound 2; then compound 1.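

With the unsubstituted anilino group held constant, pyridin-2-yl in place of pyridin-4-yl on an aromatic carbon gives a number 16 percentage points lower from compound 2 to compound 3 (beyond the scatter) in this assay, so at this position the way the pyridine is joined changes the read-out even though the two compounds have the same atoms. The pyridin-2-yl group therefore does not give a raised number on its own, a point that compound 1 could not settle while it also carried the methylsulfonyl group. Hydrogen in place of methylsulfonyl on an aromatic carbon now separates the two features, and the printed step of a number 36.7 percentage points lower from compound 1 to compound 3 (beyond the scatter) ties the higher number of compound 1 to the presence of the methylsulfonyl group in this pyridin-2-yl setting. No measurement at hand speaks to the reason for either step.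

On these data alone, whether the methylsulfonyl group would count the same way alongside pyridin-4-yl remains open, as compound 1 alone carries it. Also open, as far as these compounds go, is how a pyridin-3-yl group on the same carbon, or a carboxylic acid in place of the methylsulfonyl group, would read in this assay.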